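A few compounds are considered here, and "the series" means these few. Any claim that something is new, unique, unknown or untested is made for them only; others in the source may bear on it.

Compound 1, `CC(=O)N1N=C(c2cc(O)c(O)c([N+](=O)[O-])c2)CC1c1nccs1`, carries a catechol bearing a nitro group on a five-membered non-aromatic ring that holds two nitrogens and an acetyl group. In an assay on isolated protein for inhibition of Amine oxidase [flavin-containing] A (Homo sapiens), read by fluorescence (a higher number here means a weaker inhibitor, a lower number a stronger inhibitor), compound 1 gives 84600 nM. Two related compounds with an open chain instead of that ring were also measured: compound 2, `O=C(/C=C/c1cccs1)c1cc(O)c(O)c([N+](=O)[O-])c1`, gives 49900 nM, and compound 3, `O=C(/C=C/c1ccco1)c1cc(O)c(O)c([N+](=O)[O-])c1`, gives 60500 nM. All three numbers sit within the usual scatter of one another, so compound 1 is not separated from compound 2 or compound 3 in this assay.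

Compound 4, `CC(=O)N1N=C(c2cc(O)c(O)c([N+](=O)[O-])c2)CC1c1cccs1`, differs from compound 1 in one place: thiophen-2-yl in place of 1,3-thiazol-2-yl on a saturated ring carbon. For the measured compounds named here, the only measured step that resembles this swap of one five-membered aromatic ring for another is a 1.2-fold higher number from compound 2 to compound 3 (0.08 log units; within the scatter), which lies within the scatter. On that basis no step beyond the scatter is expected from compound 1 to compound 4, that is a 1.2-fold lower number from compound 1 to compound 4 (0.08 log units; within the scatter). Compound 4 is therefore estimated at 70000 nM, with a range from 30000 nM to 160000 nM.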

Compound 4, half-maximal inhibitory concentration: 86300 nM
Estimate against measurement, compound 4: 1.2-fold (0.09 log units) below; measured number inside the range.
By their numbers in this assay, from the lowest: compounds 2, 3, 1 and 4 (each within the scatter of the next).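

On the saturated ring carbon of the shared core, thiophen-2-yl in place of 1,3-thiazol-2-yl gives a 1.0-fold higher number from compound 1 to compound 4 (0.01 log units; within the scatter) in this assay. For the compounds shown here, until now, a swap of one five-membered aromatic ring for another had been seen only on the open chain, as a 1.2-fold higher number from compound 2 to compound 3 (0.08 log units; within the scatter); this step shows that on the ring carbon too, such a swap stays within the scatter, even though the hetero atoms in the group go from 2 to 1 and the hydrogen-bond acceptors from 2 to 1. No separate measurement is available to explain this result.

Still open, on these data alone, is whether a different kind of group on this ring carbon, such as an amine or a carboxylic acid, would give a step beyond the scatter. Also open, as far as these compounds go, is what a longer chain in place of the acetyl group would do.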